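A few compounds are considered here, and "the series" means these few. Any claim that something is new, unique, unknown or untested is made for them only; others in the source may bear on it.

compound 1 `Cc1cccc(NC(=O)C2(C(=O)Nc3ccc(Nc4ncc5cc(C(=O)N(C)C)n(C6CCCC6)c5n4)cc3)CC2)c1` gives 35.2%
compound 2 `CN(C)C(=O)c1cc2cnc(Nc3ccc(NC(=O)C4(C(=O)Nc5cccc(F)c5)CC4)cc3)nc2n1C1CCCC1` gives 33.2%
compound 3 `COC(=O)c1cccc(NC(=O)C2(C(=O)Nc3ccc(Nc4ncc5cc(C(=O)N(C)C)n(C6CCCC6)c5n4)cc3)CC2)c1` gives 10.5%

In a functional assay on A549 cells (Homo sapiens) for inhibition, read by CCK-8 assay, with a stated time of 72 h, tested at 1 uM (on this read-out higher numbers stand for more inhibition of growth at the one concentration tested and lower numbers for less inhibition of growth), compound 3 stands lowest of the three (10.5%). Compound 4 `CN(C)C(=O)c1cc2cnc(Nc3ccc(NC(=O)C4(C(=O)Nc5cccc(C(F)(F)F)c5)CC4)cc3)nc2n1C1CCCC1` keeps the rest of compound 3 and changes one group: trifluoromethyl in place of methoxycarbonyl on an aromatic carbon. In words, trifluoromethyl takes the place of methoxycarbonyl on an aromatic carbon.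

Two measured steps put methoxycarbonyl on this same carbon, and both are modest drops: a number 24.7 percentage points lower from compound 1 to compound 3 (beyond the scatter) and a number 22.7 percentage points lower from compound 2 to compound 3 (beyond the scatter). A third step swaps methyl for fluoro and stays within the scatter: a number 2 percentage points lower from compound 1 to compound 2 (within the scatter). So the two compounds without methoxycarbonyl sit close together, and compound 3 sits apart from them. Going by the values given here, none of the measured compounds carries trifluoromethyl, so the expectation rests on treating it like methyl and fluoro, which is an assumption. On that basis a modest rise is expected, and the estimated change is this (a number 19.5 percentage points higher from compound 3 to compound 4 (beyond the scatter)). The estimate for compound 4 is 30% (expected range 15% to 47%).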

Compound 4, percent growth inhibition at one concentration: 15.7%
The estimate for compound 4 lay 14.3 percentage points above the measured number; low and high end bracket the measured number.
By their numbers in this assay, from the lowest: compounds 3 and 4 (each within the scatter of the next); then compounds 2 and 1 (each within the scatter of the next).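

In this assay, replacing methoxycarbonyl with trifluoromethyl on this aromatic carbon gives a number 5.2 percentage points higher from compound 3 to compound 4 (within the scatter), so the two groups cannot be told apart here. Trifluoromethyl instead parts from fluoro and methyl, with a number 17.5 percentage points lower from compound 2 to compound 4 (beyond the scatter) and a number 19.5 percentage points lower from compound 1 to compound 4 (beyond the scatter), which shows that the low numbers at this position do not belong to methoxycarbonyl alone, even though methoxycarbonyl has hydrogen-bond acceptors and trifluoromethyl has none. Nothing measured here explains why these groups separate in this way.

Going by these compounds, it remains open whether an amine, a carboxylic acid or a plain hydrogen on this carbon would group with methyl and fluoro or with methoxycarbonyl and trifluoromethyl. A single tested concentration also leaves open whether this grouping would hold at other concentrations.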